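Swapping the Ethyl on the Cyclohexyl Ring for Fluorine

The source may hold more compounds than are shown below. What is called first, only, known or untested is meant among the compounds shown, and "the series" means these compounds.

Within the data shown here, compound 2 `CCC1CCC(c2nc(C(F)(F)F)ccc2CNC(=O)C(C)c2ccc(NS(C)(=O)=O)c(F)c2)CC1` gives 0.3 nM in an assay on CHO cells for antagonist activity at transient receptor potential cation channel subfamily V member 1 (Homo sapiens), read by FLIPR and calcium flux (on this read-out higher numbers stand for weaker inhibition and lower numbers for stronger inhibition), the lowest of the two numbers measured so far. Compound 1 `CCCCCCc1nc(C(F)(F)F)ccc1CNC(=O)C(C)c1ccc(NS(C)(=O)=O)c(F)c1` gives 1.6 nM in this assay. Among the measured compounds shown here, the single measured step, a 5.3-fold lower number from compound 1 to compound 2 (0.73 log units; beyond the scatter), shows the effect of turning the open hexyl chain into a saturated ring. Compound 3 `CC(C(=O)NCc1ccc(C(F)(F)F)nc1C1CCC(F)(F)CC1)c1ccc(NS(C)(=O)=O)c(F)c1` keeps that ring and alters only its far end: 4,4-difluorocyclohexyl in place of 4-ethylcyclohexyl on an aromatic carbon. No measured step involves a fluorinated ring, so the change has no direct precedent among these compounds. The ring itself, which carried compound 2 to the strong end of the series, is retained, and the alteration is confined to one position on it. A small rise, near the edge of the scatter, is therefore expected: a 2.7-fold higher number from compound 2 to compound 3 (0.43 log units; beyond the scatter). Compound 3 is estimated at 0.8 nM, with a range from 0.2 nM to 4 nM.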

Compound 3, inhibition constant: 1.5 nM
The estimate for compound 3 lay 1.9-fold (0.27 log units) below the measured number; low and high end bracket the measured number.
By their numbers in this assay, from the lowest: compound 2; then compounds 3 and 1 (each within the scatter of the next).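

In this assay, the ring alone does not secure the low number: replacing the ethyl of the 4-ethylcyclohexyl group with two fluorines gives a 5.0-fold higher number from compound 2 to compound 3 (0.70 log units; beyond the scatter). Against the open chain, the 4,4-difluorocyclohexyl group gives a 1.1-fold lower number from compound 1 to compound 3 (0.03 log units; within the scatter), so the advantage compound 2 holds over compound 1 does not carry over to compound 3. No measurement available here explains this difference.

The compounds shown leave open whether the ethyl itself matters or whether the two fluorines are what raise the number, a question that plain cyclohexyl, 4-methylcyclohexyl and 4-propylcyclohexyl groups could help to answer. On these data alone, it also remains open how a ring carrying a single fluorine, a hydroxyl or an amine would compare.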